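Ethyl ester to free acid in the series

A few compounds are considered here, and "the series" means these few. Any claim that something is new, unique, unknown or untested is made for them only; others in the source may bear on it.

In a functional assay on the whole organism (strain Hartley) for inhibition, with Cavia porcellus as the target, with stated times of 15 min and 2 min (a lower number here means that less compound is needed, a higher number that more compound is needed for the effect), compound 1 `CCCCC1([C@H](O)/C=C/C2CCC(=O)[C@@H]2CCCCCC(=O)O)CCC1` gives 0.032 mg/kg and compound 2 `CCCCC1([C@H](O)/C=C/C2[C@H](O)CC(=O)[C@@H]2C/C=C\CCCC(=O)O)CCC1` gives 0.00251 mg/kg as its number. Compound 3 `CCCCC1([C@H](O)/C=C/C2CCC(=O)[C@@H]2C/C=C\CCCC(=O)OCC)CCC1` gives 0.135 mg/kg as the highest of the three numbers, beyond the scatter from both others. Compound 4 `CCCCC1([C@H](O)/C=C/C2CCC(=O)[C@@H]2C/C=C\CCCC(=O)O)CCC1` is still unmeasured and differs from compound 3 by hydrogen in place of ethyl on an oxygen next to a carbonyl group with hydrogen in place of ethyl on an oxygen next to a carbonyl group, so ethoxycarbonyl becomes carboxy. Among the measured compounds shown here, no measured pair shows this change alone. Compound 4 shares the carboxy group with compound 1, which stands at 0.032 mg/kg in this assay and lies lower than compound 3, so a step to a lower number, beyond the scatter, is expected. The expected size is a 4.5-fold lower number from compound 3 to compound 4 (0.65 log units; beyond the scatter) in this estimate. For compound 4 the estimated value is 0.03 mg/kg within an estimated range of 0.008 mg/kg to 0.12 mg/kg for this measurement.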

Compound 4, dose for half-maximal effect: 0.00767 mg/kg
For compound 4 the middle estimate is 3.9-fold (0.59 log units) above the measured one; measured number below the stated range.
By their numbers in this assay, from the lowest: compound 2; then compound 4; then compound 1; then compound 3.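

In this assay, among the compounds shown here, ethoxycarbonyl to carboxy, with hydrogen in place of ethyl on an oxygen next to a carbonyl group, gives an 18-fold lower number from compound 3 to compound 4 (1.25 log units; beyond the scatter), the first reading of this change alone and the largest of the new steps. In the chain, 5-carboxypent-1-en-1-yl in place of 4-carboxybutyl gives a 4.2-fold lower number from compound 1 to compound 4 (0.62 log units; beyond the scatter). Hydrogen in place of hydroxy on a saturated ring carbon gives a 3.1-fold higher number from compound 2 to compound 4 (0.49 log units; beyond the scatter).

Nothing available bears on the origin of these steps. As far as these compounds go, whether a methyl ester or a primary amide in place of the carboxy group would stay nearer compound 4 or compound 3 remains open.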